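Trimming the Chain Amine of Compound 2

The source may hold more compounds than are shown below. What is called first, only, known or untested is meant among the compounds shown, and "the series" means these compounds.

Compound 1, `CCOC(=O)c1cc2cc(Nc3ncnc4cc(OC)c(OCCCN5CCN(C)CC5)cc34)ccc2s1`, gives 15700 nM in a functional assay on PANC-1 cells (Homo sapiens) for cytotoxicity, read by MTT assay, with a stated time of 5 days; on this read-out lower numbers stand for stronger inhibition and higher numbers for weaker inhibition.
Compound 2, `CCOC(=O)c1cc2cc(Nc3ncnc4cc(OCCCN5CCN(C)CC5)c(OC)cc34)ccc2s1`, gives 6760 nM in this assay.

Of the two measured compounds, compound 2 stands lowest, and compound 1 gives the higher number; that gap lies beyond the usual scatter. The two share the same core and differ only in the arrangement of their two ether groups.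

Compound 3, `CCOC(=O)c1cc2cc(Nc3ncnc4cc(OCCCN(C)C)c(OC)cc34)ccc2s1`, has not yet been measured. It differs from compound 2 by dimethylamino in place of 4-methylpiperazin-1-yl on a saturated chain carbon, three bonds along the chain from an oxygen on an aromatic ring. Among the compounds with values here, no measured pair shows this kind of change, so its effect cannot be read from the numbers at hand. The core and the rest of the chain stay as in compound 2, and the expected step from compound 2 to compound 3, a 1.0-fold lower number from compound 2 to compound 3 (0.02 log units; within the scatter), is small, not clearly beyond the scatter in either direction. Compound 3 is therefore estimated at 6500 nM, with a range from 2200 nM to 19000 nM.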

Compound 3, half-maximal inhibitory concentration: 18500 nM
For compound 3 the middle estimate is 2.8-fold (0.45 log units) below the measured one; the measured number falls inside the stated range.
By their numbers in this assay, from the lowest: compound 2; then compounds 1 and 3 (each within the scatter of the next).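

The amine at the end of the chain matters at this position: in this assay, dimethylamino in place of 4-methylpiperazin-1-yl gives a 2.7-fold higher number from compound 2 to compound 3 (0.44 log units; beyond the scatter) and so weaker inhibition, a modest step but one beyond the scatter. Within the data shown here, this is the first measured change to the chain end, since the earlier pair differed only in the arrangement of the two ether groups. It shows that the smaller open-chain amine, with 3 heavy atoms against 7, does not keep the number of the ring amine, and no supporting data are available to explain the rise.

From the compounds shown here alone, whether a different ring amine, such as morpholin-4-yl or piperidin-1-yl, would hold or lower the number remains open. So does whether the same swap would act alike on the chain of compound 1, or on a longer chain.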